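A few compounds are considered here, and "the series" means these few. Any claim that something is new, unique, unknown or untested is made for them only; others in the source may bear on it.

Measured so far:
compound 1, `Oc1ccc(-c2cc(-c3cccs3)cc(-c3ccc(O)cc3)n2)cc1` — in a functional assay on HeLa cells (Homo sapiens) for cytotoxicity, read by CCK-8 assay (on this read-out lower numbers stand for stronger inhibition and higher numbers for weaker inhibition), compound 1 gives > 50000 nM, which is a limit of the assay and not a number.
compound 2, `Oc1ccc(-c2cc(-c3ccoc3)cc(-c3ccc(O)cc3)n2)cc1` — in this assay compound 2 gives 3420 nM.
compound 3, `Oc1ccc(-c2cc(-c3ccccn3)cc(-c3ccccc3O)n2)cc1` — in this assay compound 3 gives > 50000 nM, again a limit and not a number.

Compound 3 therefore stands at the limit, where two of the three values sit (the limit of > 50000 nM in this assay, at which 2 of the 3 values shown sit). Among the compounds with values here, the single measured step, an at least 14-fold lower number from compound 1 to compound 2 (1.16 log units; beyond the scatter), exchanges the five-membered ring and leaves both hydroxyphenyl groups untouched, so it does not bear on the present change. Compound 4, `Oc1ccc(-c2cc(-c3ccccn3)cc(-c3ccc(O)cc3)n2)cc1`, differs from compound 3 by 4-hydroxyphenyl in place of 2-hydroxyphenyl on an aromatic carbon. Within the data shown here, no measured step speaks to moving the hydroxyl, and compound 4 keeps the pyridin-2-yl group of compound 3, which sits at the limit. Compound 4 is therefore expected near the limit as well, estimated at 40000 nM with a range of 5000 nM to 200000 nM. The expected step is an at least 1.2-fold lower number from compound 3 to compound 4 (0.09 log units; that floor lies within the scatter), within the scatter.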

Compound 4, half-maximal inhibitory concentration: > 50000 nM
Compound 4: no number, only a limit; the forecaster's own chance of this, stated with the estimate: 60%; middle value at least 1.2-fold (0.09 log units) from the limit.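

In this assay, compound 4 gives a limit and not a number, so moving the hydroxyl to 4-hydroxyphenyl yields no readable value while pyridin-2-yl stays in place. With both 4-hydroxyphenyl groups kept, pyridin-2-yl in place of furan-3-yl gives an at least 14-fold higher number from compound 2 to compound 4 (1.16 log units; beyond the scatter), which leaves furan-3-yl as the only group shown here that gives a number. The two steps joining compound 4 to the other limit compounds cannot be read, and the values crowd at one ceiling: the limit of > 50000 nM in this assay, at which 3 of the 4 values shown sit.

Open, from the compounds shown here alone, is whether a primary amine or a carboxylic acid on that aromatic carbon would give a number. Also open, going by these compounds, is whether furan-3-yl paired with 2-hydroxyphenyl would stay near compound 2, at 3420 nM.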